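The source may hold more compounds than are shown below. What is called first, only, known or untested is meant among the compounds shown, and "the series" means these compounds.

In a functional assay on PC-3 cells (Homo sapiens) for antiproliferative activity, read by sulforhodamine B assay, with a stated time of 48 h (a higher number here means a weaker inhibitor of growth, a lower number a stronger inhibitor of growth), the three measured compounds read as follows.

Compound 1 `CC(C)CCc1c(OCCCCCCC(=O)NO)ccc2c1OC(=O)CC2` gives > 30000 nM, which is a limit of this assay rather than a number.
Compound 2 `CC(C)CCc1c(OCCCCC(=O)NO)ccc(CCC(=O)NO)c1O` gives 14400 nM.
Compound 3 `CC(C)CCc1c(OCCCCCC(=O)NO)ccc2c1OC(=O)CC2` gives > 30000 nM, again a limit rather than a number.

Compound 3 and compound 1 share a core and differ by (hydroxycarbamoyl)methyl in place of hydroxycarbamoyl on a saturated chain carbon, five bonds along the chain from an oxygen on an aromatic ring. The step that the two limits leave unreadable from compound 3 to compound 1 cannot be read, since both sit at the limit of > 30000 nM in this assay, at which 2 of the 3 values shown sit. The difference between the core of compound 2 and the core of compound 3 is not broken down here.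

Compound 4 `CC(C)CCc1c(OCCCCCC(=O)NO)ccc(CCC(=O)NO)c1O` is still unmeasured. It differs from compound 2 by (hydroxycarbamoyl)methyl in place of hydroxycarbamoyl on a saturated chain carbon, four bonds along the chain from an oxygen on an aromatic ring, the same kind of change as from compound 3 to compound 1, though here the place is four bonds along the chain from the oxygen on the aromatic ring rather than five. With the measured step unreadable, the expectation rests on compound 2 and its value 14400 nM. The expected step is a 1.0-fold higher number from compound 2 to compound 4 (0.02 log units; within the scatter). Compound 4 is therefore estimated at about 15000 nM in this assay, likely between 6000 nM and 40000 nM.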

Compound 4, concentration for 50% growth inhibition: 2520 nM
Estimate against measurement, compound 4: 6.0-fold (0.77 log units) above; measured number outside the range, below it.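

In this assay, swapping hydroxycarbamoyl for (hydroxycarbamoyl)methyl at the end of the chain on the core of compound 2 gives a 5.7-fold lower number from compound 2 to compound 4 (0.76 log units; beyond the scatter), so on this core the change makes a stronger inhibitor of growth. On the core shared by compound 3 and compound 1, the same change cannot be read, since both compounds sit at a limit and not at a number: the limit of > 30000 nM in this assay, at which 2 of the 4 values shown sit. The result therefore rests on one pair, and it shows neither that the change carries over from one core to the other nor that it fails to.

On these data alone, it remains open whether a longer chain on the core of compound 4 would lower the number further. As far as these compounds go, it is also open whether a carboxylic acid in place of the hydroxycarbamoyl ends would keep any of the activity of compound 4.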